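A few compounds are considered here, and "the series" means these few. Any claim that something is new, unique, unknown or untested is made for them only; others in the source may bear on it.

Measured so far:
compound 1 `CCCCCCCC/C=C\CCCCCCC(=O)c1nc2cccnc2o1` — 11 nM
compound 2 `CCCCCCCC/C=C\CCCCCCC(=O)c1ncc(-c2ccccn2)o1` — 18 nM
compound 3 `CCCCCCCC/C=C\CCCCCCC(=O)c1nc2c(C)cccc2o1` — > 100000 nM

Three compounds sharing the same core have been run in an assay on isolated protein for inhibition of Fatty-acid amide hydrolase 1 (Homo sapiens); a lower number here means a stronger inhibitor, a higher number a weaker inhibitor. Compound 1 gives 11 nM. Compound 2 gives 18 nM, the highest of the two numbers shown, but its nearest neighbour, compound 1, sits within the usual scatter of it, so the two cannot be ordered. Compound 3 returns only a limit, > 100000 nM, which is not a number; it marks (the limit of > 100000 nM in this assay, at which 1 of the 3 values shown sits).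

Among the compounds with values here, no pair of measured compounds differs in a single place, so no measured step is available. The next compound, compound 4 `CCCCCCCC/C=C\CCCCCCC(=O)c1ncc(-c2ccoc2)o1`, differs from compound 2 at one position: furan-3-yl in place of pyridin-2-yl on an aromatic carbon. Going by these compounds, compound 1 and compound 2 run alike in this assay, so the position tolerates at least one aryl group, but whether furan-3-yl behaves like pyridin-2-yl there is untested. Compound 4 is expected to lose some potency, with a 2.2-fold higher number from compound 2 to compound 4 (0.35 log units; beyond the scatter) as the estimated step, though a step within the scatter would not surprise. For compound 4 the estimate in this assay is 40 nM, with a range from 12 nM to 150 nM.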

Compound 4, inhibition constant: 610 nM
Compound 4: middle estimate off by 15-fold (1.18 log units), on the low side, and the stated range ends below it.
By their numbers in this assay, from the lowest: compounds 1 and 2 (each within the scatter of the next); then compound 4. At a limit, above all of these: compound 3.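

In this assay, the aromatic carbon next to the ring oxygen is not indifferent to which aryl group it carries: furan-3-yl in place of pyridin-2-yl gives a 34-fold higher number from compound 2 to compound 4 (1.53 log units; beyond the scatter), a large step. Tolerance of pyridin-2-yl at this position therefore does not extend to every small aromatic ring, and a single hetero-aromatic swap is enough to separate the two compounds clearly. Both groups have the same hydrogen-bond donor and acceptor counts and no net charge, so those counts do not separate them, what differs being the ring size and the hetero atom, and nothing shown gives a measured reason for the step.

Going by these compounds, this one pair changes ring size and hetero atom together, so it remains open which of the two carries the step, and how a phenyl, a pyridin-3-yl or a furan-2-yl group would read at the same carbon in this assay. Also open, on these data alone, is whether a step of this size would hold with a shorter chain in place of the shared chain.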